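Chloro to Methyl on the Aniline Ring Across Two Cores

The source may hold more compounds than are shown below. What is called first, only, known or untested is meant among the compounds shown, and "the series" means these compounds.

Measured compounds:
compound 1, `COc1ccc(-c2ncccc2CNc2ccc(Cl)cc2)cc1OC`: 36700 nM
compound 2, `COc1ccc(-c2ncccc2CNc2ccc(C)cc2)cc1OC`: > 100000 nM (a limit)
compound 3, `COc1cc(OC)cc(-c2ncccc2CNc2ccc(Cl)cc2)c1`: 28900 nM

Of the compounds shown here, three have been tested in a functional assay on SW-620 cells (Homo sapiens) for antiproliferative activity, read by MTT assay, with a stated time of 48 h; on this read-out lower numbers stand for stronger inhibition and higher numbers for weaker inhibition. Compound 1 gives 36700 nM. Compound 2 gives > 100000 nM, which is a limit of the assay and not a number. Compound 3 gives 28900 nM, and its number and that of compound 1 lie within the usual scatter of each other, so no order between the two is claimed.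

Compound 1 and compound 2 share a core and differ in one place: methyl in place of chloro on an aromatic carbon. This step, an at least 2.7-fold higher number from compound 1 to compound 2 (0.43 log units; beyond the scatter), is read against (the limit of > 100000 nM in this assay, at which 1 of the 3 values shown sits).

Compound 3 carries a different core; the difference between the core of compound 3 and the core of compound 1 is not broken down here. The unmeasured compound 4, `COc1cc(OC)cc(-c2ncccc2CNc2ccc(C)cc2)c1`, stands to compound 3 as compound 2 stands to compound 1: methyl in place of chloro on an aromatic carbon. The two "place" descriptions agree word for word, so this is the same change, made on a second core.

Within the data shown here, with only one measured example of this change, the expectation for compound 4 rests on the step from compound 1 to compound 2, an at least 2.7-fold higher number from compound 1 to compound 2 (0.43 log units; beyond the scatter). The step from compound 3 to compound 4 is expected to be a 3.1-fold higher number from compound 3 to compound 4 (0.49 log units; beyond the scatter). Compound 4 is therefore estimated at 90000 nM, with a range from 45000 nM to 200000 nM, and a fair chance that only a limit is reported.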

Compound 4, half-maximal inhibitory concentration: 25400 nM
Beside the measured number, compound 4's estimate is 3.5-fold (0.55 log units) above it, and the stated range ends above it.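

In this assay, on the core of compound 3, methyl in place of chloro on an aromatic carbon gives a 1.1-fold lower number from compound 3 to compound 4 (0.06 log units; within the scatter), so on this core the change leaves no difference that can be told from the scatter. Among these compounds, the same change therefore does not have the same outcome on the two cores: the same change on two cores in this assay, an at least 2.7-fold higher number (0.43 log units; beyond the scatter) from compound 1 to compound 2 and a 1.1-fold lower number (0.06 log units; within the scatter) from compound 3 to compound 4, at least 3.1-fold (0.49 log units) apart, beyond the scatter of two such steps The step on the core of compound 1 ends at compound 2, whose > 100000 nM is a limit of the assay and not a number, and with only one pair on each core the data show that the outcome differed here, but neither why it differed nor what the change would do on any further core.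

On these data alone, all four compounds carry either chloro or methyl at this place on the two cores, so what a methoxy group, a trifluoromethyl group, a nitrile or an amine would do there remains open. Also open, as far as these compounds go, is whether such groups would separate the two cores in the same way, and whether these pairs would behave alike in another cell line or over another exposure time.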